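The source may report more compounds than this note shows. Statements on the series, on what has been measured and on what is new or still open speak of the compounds shown alone.

Measured compounds in an ADME assay on isolated protein for pharmacokinetics, with UDP-glucuronosyltransferase 1A9 (Homo sapiens) as the target, read by LC-MS, with a stated time of 60 min, at 37 degrees C, tested at 1 uM, in the presence of a further agent that is not named here; a higher number here means that the compound lasts longer, a lower number that the compound disappears faster:
compound 1, `NS(=O)(=O)CC(=O)NCCSc1nonc1/C(=N/O)Nc1cccc(Cl)c1`: 0.9 h
compound 2, `NS(=O)(=O)CC(=O)NCCSc1nonc1/C(=N/O)Nc1ccc(F)c(C(F)F)c1`: > 3 h, a limit of the assay
compound 3, `CC1(C(=O)NCCSc2nonc2/C(=N/O)Nc2ccc(F)c(C(F)F)c2)CCN1`: > 3 h, a limit of the assay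

Compound 2 stands at the upper end of what this assay reports: its value is a limit, not a number, and (the limit of > 3 h in this assay, at which 2 of the 3 values shown sit). Compound 3, which differs from compound 2 on the carbonyl carbon, gives a step that the two limits leave unreadable from compound 2 to compound 3, so that pair says nothing about size.

The unmeasured compound 4, `N#Cc1cccc(N/C(=N\O)c2nonc2SCCNC(=O)CS(N)(=O)=O)c1`, differs from compound 2 only on the aryl ring: 3-cyanophenyl in place of 3-(difluoromethyl)-4-fluorophenyl on an amine nitrogen. Among the compounds with values here, the one measured step at this place is an at least 3.3-fold higher number from compound 1 to compound 2 (0.52 log units; beyond the scatter). Compound 1 with 3-chlorophenyl sits at 0.9 h. Compound 2 with 3-(difluoromethyl)-4-fluorophenyl reaches the limit of the assay. Within the data shown here, no measured compound carries 3-cyanophenyl, so the direction rests on that single step. Since compound 4 gives up the group that raised the number from compound 1, a fall below the limit is expected, though not necessarily back to where compound 1 stands. Compound 4 is therefore estimated at 1.8 h, with a likely range from 0.7 h to 4.5 h, which means an expected step of an at least 1.6-fold lower number from compound 2 to compound 4 (0.22 log units; that floor lies within the scatter).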

Compound 4, half-life: > 3 h
Compound 4: only a limit was reported (the forecaster's own chance of this, stated with the estimate: 30%); middle value at least 1.6-fold (0.22 log units) away from the limit.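

In this assay compound 4 also gives a limit and not a number, so 3-cyanophenyl ends at the same reporting limit as 3-(difluoromethyl)-4-fluorophenyl: the limit of > 3 h in this assay, at which 3 of the 4 values shown sit.

The readable change is cyano in place of chloro on an aromatic carbon, which gives an at least 3.3-fold higher number from compound 1 to compound 4 (0.52 log units; beyond the scatter). Set beside an at least 3.3-fold higher number from compound 1 to compound 2 (0.52 log units; beyond the scatter), this shows that the rise at this place on the amine nitrogen is not tied to 3-(difluoromethyl)-4-fluorophenyl, and 3-chlorophenyl is the only aryl group shown whose compound has a value that is not a limit. The step between the two compounds with these other aryl groups cannot be read, as both values are limits, so nothing can be said of its size or direction.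

On these data alone, how far compound 2, compound 3 and compound 4 lie beyond the limit stays open, and with it any ranking of 3-cyanophenyl against 3-(difluoromethyl)-4-fluorophenyl. Also open, as far as these compounds go, is how a methoxy group or an amine in place of the cyano on the aryl ring would read, and whether 3-cyanophenyl would give the same limit with the group on the carbonyl carbon of compound 3.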